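The source may hold more compounds than are shown below. What is called first, only, known or untested is meant among the compounds shown, and "the series" means these compounds.

Measured so far in an assay on CHO cells for displacement of a labelled ligand from prostaglandin E2 receptor EP3 subtype (Homo sapiens), read by radioligand binding; a lower number here means a stronger inhibitor, a higher number a weaker inhibitor:
compound 1, `CC(C)C(Nc1nccs1)c1ccc(-c2ccc3cccc(F)c3c2)[nH]c1=O`, 9.4 nM;
compound 2, `CC(C)C(Nc1nnc[nH]1)c1ccc(-c2ccc3cccc(F)c3c2)[nH]c1=O`, 22 nM;
compound 3, `Cc1c[nH]c(C(c2ccc(-c3ccc4cccc(F)c4c3)[nH]c2=O)C(C)C)n1`, 12 nM.

Compound 3 sits second highest of these three numbers, nearest compound 1 at a 1.3-fold higher number from compound 1 to compound 3 (0.11 log units; within the scatter) and furthest from compound 2 at a 1.8-fold lower number from compound 2 to compound 3 (0.26 log units; within the scatter), both within the scatter. Compound 4, `CC(C)C(Cc1nnc[nH]1)c1ccc(-c2ccc3cccc(F)c3c2)[nH]c1=O`, is still unmeasured; it differs from compound 3 by (4H-1,2,4-triazol-3-yl)methyl in place of 4-methyl-1H-imidazol-2-yl on a saturated chain carbon bound to an aromatic carbon and a saturated chain carbon. Among the compounds with values here, two steps bear on it: a 2.3-fold higher number from compound 1 to compound 2 (0.37 log units; beyond the scatter), where a triazole replaced a thiazole and the number rose modestly, and a 1.8-fold lower number from compound 2 to compound 3 (0.26 log units; within the scatter), within the scatter. Compound 4 is therefore expected to lie close to compound 2, with a modest rise from compound 3, a 2.1-fold higher number from compound 3 to compound 4 (0.32 log units; beyond the scatter). Compound 4 is estimated at 25 nM, between 10 nM and 60 nM.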

Compound 4, inhibition constant in the prostaglandin E2 receptor EP3 subtype assay: 10 nM
The estimate for compound 4 lay 2.5-fold (0.40 log units) above the measured number; the measured number falls inside the stated range.
By their numbers in the prostaglandin E2 receptor EP3 subtype assay, from the lowest: compounds 1, 4, 3 and 2 (each within the scatter of the next, the first and the last beyond it).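

In the prostaglandin E2 receptor EP3 subtype assay the (4H-1,2,4-triazol-3-yl)methyl group shows no separation from 4-methyl-1H-imidazol-2-yl, a 1.2-fold lower number from compound 3 to compound 4 (0.08 log units; within the scatter), or from (1,3-thiazol-2-yl)amino, a 1.1-fold higher number from compound 1 to compound 4 (0.03 log units; within the scatter). The same triazole does better through a carbon link than through an amine nitrogen, a 2.2-fold lower number from compound 2 to compound 4 (0.34 log units; beyond the scatter). In a physicochemical assay for solubility, measured as kinetic solubility, at pH 2 (a higher number here means a more soluble compound, a lower number a less soluble compound), compound 3 gives 6300 nM and compound 4 gives 28400 nM, so at this position the change brings higher solubility with no measurable cost in binding: the measured solubility of compound 3, 6300 nM, and of compound 4, 28400 nM, a 4.5-fold higher number (0.65 log units; beyond the scatter)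

The compounds shown leave open whether a longer chain to the triazole, or a carboxylic acid in its place, would keep both results.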